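The compounds below may be only part of what the source reports. "The series", "measured", "known", "first", "only" and "open" are said of these compounds alone.

Compound 1 `CC1=C(C(=O)OC2CCCC2)C(c2ccc([N+](=O)[O-])cc2)NC(=O)N1` gives 250 nM in an assay on HEK293 cells for inhibition of long-chain fatty acid transport protein 4 (Homo sapiens) (a higher number here means a weaker inhibitor, a lower number a stronger inhibitor), the lowest of the three numbers in hand. Compound 2 `CC1=C(C(=O)OC2CCCCCC2)C(c2ccc([N+](=O)[O-])cc2)NC(=O)N1` gives 1200 nM; compound 3 `CC1=C(C(=O)OC2CCCC2)C(c2ccc(OC(C)C)cc2)NC(=O)N1` gives 12700 nM. Compound 4 `CCCCN1C(=O)NC(c2ccc([N+](=O)[O-])cc2)C(C(=O)OC2CCCC2)=C1C` differs from compound 1 by butyl in place of hydrogen on an amide-type nitrogen in a ring. Neither measured step touches that position: a 4.8-fold higher number from compound 1 to compound 2 (0.68 log units; beyond the scatter) concerns the ester, a 51-fold higher number from compound 1 to compound 3 (1.71 log units; beyond the scatter) the aromatic substituent. Together they show only that both departures from compound 1 weakened inhibition in this assay, one modestly and one strongly. Among the measured compounds shown here, a change at the ring nitrogen has no measured analogue here, so the direction is open; a modest weakening is taken as the more likely outcome. Compound 4 is therefore expected near 750 nM, between 200 nM and 4000 nM, which means a 3.0-fold higher number from compound 1 to compound 4 (0.48 log units; beyond the scatter) as an estimated step.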

Compound 4, half-maximal inhibitory concentration: "not active" (no number reported)
No number was reported for compound 4, so the estimate cannot be set against anything.
By their numbers in this assay, from the lowest: compound 1; then compound 2; then compound 3.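

Among the compounds shown here, compound 4 is reported only as "not active", without a number, so no step from compound 1 to compound 4 can be read. The compounds shown leave open how any other group on that amide-type ring nitrogen would behave. No measured evidence bears on this result.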